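The source may report more compounds than this note shows. Statements on the series, on what has been measured and on what is new or still open speak of the compounds shown alone.

In a functional assay on HEK293 cells for agonist activity at Glucose-dependent insulinotropic receptor (Homo sapiens), read by cAMP accumulation, with a stated time of 30 min (a lower number here means a smaller maximal response, a higher number a larger maximal response), compound 1 `Cc1cc2c(c(Oc3cccc(NS(=O)(=O)c4ccc(Cl)cc4)c3)n1)C(=O)N(C1CC1)C2=O` gives 111%, and compound 2 `Cc1cc2c(c(Oc3cccc(NS(=O)(=O)c4ccc(Cl)cc4)c3)n1)C(=O)NC2=O` gives 109%, the lowest of the two numbers, with compound 1 its nearest neighbour. Among the compounds with values here, the one step recorded, a number 2 percentage points lower from compound 1 to compound 2 (within the scatter), swaps a hydrogen for a cyclopropyl on the same nitrogen and stays within the scatter. Compound 3 `Cc1cc2c(c(Oc3cccc(NS(=O)(=O)c4ccc(Cl)cc4)c3)n1)C(=O)N(C)C2=O` differs from compound 2 by methyl in place of hydrogen on an amide-type nitrogen in a ring. Since that earlier step was flat, no step beyond the scatter is expected here. For compound 3 the estimate is 110%, with a range from 96% to 124%. The step this estimate means, a number 1 percentage points higher from compound 2 to compound 3 (within the scatter), is expected to be small.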

Compound 3, largest response reached (reported as efficacy), in percent of the reference or control that the assay uses: 122%
Estimate against measurement, compound 3: 12 percentage points below; measured number inside the range.
By their numbers in this assay, from the lowest: compounds 2 and 1 (each within the scatter of the next); then compound 3.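

The earlier swap on this nitrogen stayed within the scatter, but it did not mean that the group there makes no difference: methyl brings a number 13 percentage points higher from compound 2 to compound 3 (beyond the scatter), and also a number 11 percentage points higher from compound 1 to compound 3 (beyond the scatter). The maximal response therefore does not rise steadily from hydrogen through methyl to cyclopropyl. Nothing available explains why methyl stands apart. On these data alone, whether an ethyl group or a longer chain on this nitrogen would keep, raise or lose the higher response remains open, and so does whether methyl would have the same effect on a different core.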